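This account rests on a few compounds, and the source may have more. Where it says the series, first, only, none or still open, it means among the compounds named here.

Measured in an assay on membranes from Sf9 cells for displacement of a labelled ligand from histamine H2 receptor (Homo sapiens), read by scintillation counting, with a stated time of 60 min; on this read-out lower numbers stand for stronger inhibition and higher numbers for weaker inhibition:
compound 1 `Cc1nc(N)sc1CCCN/C(N)=N/C(=O)N[C@H](C)c1ccccc1`: 17.8 nM
compound 2 `Cc1nc(N)sc1CCCN/C(N)=N/C(=O)NCC(C)CCc1ccccc1`: 63.1 nM
compound 3 `Cc1nc(N)sc1CCCN/C(N)=N/C(=O)NCc1ccco1`: 10.5 nM

Compound 3 shows the lowest of the three numbers in this assay. Its nearest neighbour is compound 1; the step of a 1.7-fold lower number from compound 1 to compound 3 (0.23 log units; within the scatter) lies within the scatter, so compounds 1 and 3 cannot be ranked against each other. Compound 2 stands furthest off, its number beyond the scatter from compound 3.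

Compound 4 `Cc1nc(N)sc1CCCN/C(N)=N/C(=O)NCC(C)C1CCCCC1` has not been measured. Against compound 3 it carries 1-cyclohexylethyl in place of furan-2-yl on a saturated chain carbon bound to an amide-type nitrogen. Within the data shown here, no measured step covers this change. Among the measured compounds shown here, the only step at hand, a 1.7-fold lower number from compound 1 to compound 3 (0.23 log units; within the scatter), exchanges one ring-bearing group for another and is within the scatter, so it offers no direction. For the measured compounds named here, the nearest point of comparison is compound 2, the one measured compound that also carries a methyl-branched saturated chain on the amide-type nitrogen; in this assay compound 2 gives 63.1 nM, the highest number of the three. On that basis a weakening is expected, and the step from compound 3 to compound 4 is estimated as a 3.8-fold higher number from compound 3 to compound 4 (0.58 log units; beyond the scatter). For compound 4 the expected value is 40 nM, with a range from 15 nM to 120 nM.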

Compound 4, inhibition constant: 39.8 nM
Compound 4: middle estimate off by 1.0-fold (0.00 log units), on the high side; the range from low to high includes it.
By their numbers in this assay, from the lowest: compounds 3 and 1 (each within the scatter of the next); then compounds 4 and 2 (each within the scatter of the next).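

In this assay, among these compounds, the step of a 3.8-fold higher number from compound 3 to compound 4 (0.58 log units; beyond the scatter) is the only single-place change that lies beyond the scatter, so this position does respond to the group it carries: 1-cyclohexylethyl in place of furan-2-yl on a saturated chain carbon bound to an amide-type nitrogen gives a modest weakening. Within the methyl-branched chains the step of a 1.6-fold lower number from compound 2 to compound 4 (0.20 log units; within the scatter) stays within the scatter, so cyclohexyl and phenethyl on a saturated chain carbon bound to two saturated chain carbons cannot be ranked, and an aromatic ring at this place is not required for a number in this range. Nothing measured here explains either step.

Since 1-cyclohexylethyl differs from furan-2-yl in both its ring and its branched chain, the compounds shown do not separate the two, and a cyclohexyl in place of furan-2-yl on the same unbranched carbon would do so. Also open, going by these compounds, is how this position takes an amine, a carboxylic acid or a longer chain ending in cyclohexyl.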